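Two Triazole Pairs Tested for Antiproliferative Activity

The source may hold more compounds than are shown below. What is called first, only, known or untested is meant among the compounds shown, and "the series" means these compounds.

Compound 1 `Cc1ccc(-c2cn(C/C=C3\OC(=O)C(OCc4ccccc4)=C3OCc3ccccc3)nn2)cc1` was tested in a functional assay on HCT-116 cells (Homo sapiens) for antiproliferative activity, read by MTT assay, with a stated time of 72 h; on this read-out lower numbers stand for stronger inhibition and higher numbers for weaker inhibition. In this assay compound 1 reaches only the limit of > 100000 nM, which is a limit of the assay and not a number. Compound 2 `O=C1O/C(=C\Cn2cc(-c3cc(F)cc(F)c3)nn2)C(OCc2ccccc2)=C1OCc1ccccc1` differs from compound 1 by 3,5-difluorophenyl in place of 4-methylphenyl on an aromatic carbon. In this assay compound 2 likewise sits at the limit of > 100000 nM. The resulting step that the two limits leave unreadable from compound 1 to compound 2 cannot be read, since both ends are limits; the evidence is the limit of > 100000 nM in this assay, at which 3 of the 3 values shown sit.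

Compound 3 `Cc1ccc(-c2cn(C[C@H](O)[C@H]3OC(=O)C(OCc4ccccc4)=C3OCc3ccccc3)nn2)cc1` carries a different core; the difference between the two cores is not broken down here. In this assay compound 3 also gives only the limit of > 100000 nM.

Compound 4 `O=C1O[C@H]([C@@H](O)Cn2cc(-c3cc(F)cc(F)c3)nn2)C(OCc2ccccc2)=C1OCc1ccccc1`, not yet measured, differs from compound 3 by 3,5-difluorophenyl in place of 4-methylphenyl on an aromatic carbon, the same change that turned compound 1 into compound 2. Since that change left compound 1 and compound 2 both at the limit, compound 4 is expected to show a step of a number no higher from compound 3 to compound 4 (the limit leaves the size open) that is likewise unreadable, and the expected value for compound 4 in this assay is estimated at 100000 nM, between 30000 nM and 300000 nM.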

Compound 4, half-maximal inhibitory concentration: 48200 nM
Beside the measured number, compound 4's estimate is 2.1-fold (0.32 log units) above it; the range from low to high includes it.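

In this assay, among these compounds, 3,5-difluorophenyl in place of 4-methylphenyl on the core of compound 3 gives an at least 2.0-fold lower number from compound 3 to compound 4 (0.31 log units; beyond the scatter), and compound 4 is the only one of the four compounds with a measured number rather than a limit. This does not show that the change carries over from one core to the other, because the same change on the core of compound 1 cannot be read, with both ends of that step being limits: the limit of > 100000 nM in this assay, at which 3 of the 4 values shown sit.

As far as these compounds go, the value of compound 3, > 100000 nM, is a limit of the assay and not a number, and the full size of the step stays open with it.

The compounds shown leave open how either core would respond to an amine or a carboxylic acid on the aromatic ring in place of 3,5-difluorophenyl. They also leave open whether a longer chain on that aromatic carbon would bring the core of compound 1 to a measurable number.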